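Swapping the amide group of compound 3

The compounds below may be only part of what the source reports. "The series", "measured", "known", "first", "only" and "open" are said of these compounds alone.

In a functional assay on Caco-2 cells (Homo sapiens) for antiproliferative activity, read by MTT assay, with a stated time of 48 h (a lower number here means a stronger inhibitor, a higher number a weaker inhibitor), compound 1 `CCn1c(C(=O)NCCCN(C)C)ccc1C(CC)(CC)c1ccc(OCCC(O)(CC)CC)c(C)c1` gives 490 nM while compound 2 `CCn1c(C(=O)NCCN(C)C)ccc1C(CC)(CC)c1ccc(OCCC(O)(CC)CC)c(C)c1` gives 1140 nM and compound 3 `CCn1c(C(=O)NCCN)ccc1C(CC)(CC)c1ccc(OCCC(O)(CC)CC)c(C)c1` gives 1740 nM as its half-maximal concentration. Compound 3 therefore stands with compound 2, as a 1.5-fold higher number from compound 2 to compound 3 (0.18 log units; within the scatter) shows, and apart from compound 1, as a 3.6-fold higher number from compound 1 to compound 3 (0.55 log units; beyond the scatter) shows. Compound 4 `CCn1c(C(=O)N(CCC#N)CCC#N)ccc1C(CC)(CC)c1ccc(OCCC(O)(CC)CC)c(C)c1` replaces the (2-aminoethyl)amino group on the carbonyl carbon (a group of 9 heavy atoms (6 carbon, 3 nitrogen; no ring) in place of a group of 4 heavy atoms (2 carbon, 2 nitrogen; no ring), on a carbonyl carbon). The nearest guides are the chain changes already measured, namely a 2.3-fold higher number from compound 1 to compound 2 (0.37 log units; beyond the scatter) and a 3.6-fold higher number from compound 1 to compound 3 (0.55 log units; beyond the scatter). None of them replaces the whole group, so the forecast is loose. The expected change is a 2.3-fold higher number from compound 3 to compound 4 (0.36 log units; beyond the scatter) in this assay and would be a modest rise. Compound 4 is estimated at 4000 nM with an expected range of 1000 nM to 15000 nM for repeat measurements.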

Compound 4, half-maximal inhibitory concentration: > 50000 nM
Compound 4: no number, only a limit (the forecaster's own chance of this, stated with the estimate: 12%); at least 12-fold (1.09 log units) between middle value and limit.
By their numbers in this assay, from the lowest: compound 1; then compounds 2 and 3 (each within the scatter of the next). At a limit, above all of these: compound 4.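

In this assay, compound 4 gives only a limit of the assay, not a number: the limit of > 50000 nM in this assay, at which 1 of the 4 values shown sits. Read against that limit, the steps are large: an at least 28-fold higher number from compound 3 to compound 4 (1.45 log units; beyond the scatter), an at least 43-fold higher number from compound 2 to compound 4 (1.64 log units; beyond the scatter) and an at least 100-fold higher number from compound 1 to compound 4 (2.00 log units; beyond the scatter). On this carbonyl carbon, replacing the whole group therefore moves the number much further than the modest chain changes among compounds 1, 2 and 3 did.

On these data alone, what remains open is which part of the change matters: the two triple bonds, or the loss of hydrogen-bond donors. A single nitrile-bearing chain, or a chain ending in a hydroxyl group or a carboxylic acid, could help separate these.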